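From Methyl to Methoxy on an Aromatic Carbon

The compounds below may be only part of what the source reports. "The series", "measured", "known", "first", "only" and "open" are said of these compounds alone.

Compound 1 `CCOC(=O)c1sc2ccccc2c1/N=N/Nc1ccccc1`: 26100 nM
Compound 2 `CCOC(=O)c1sc2ccccc2c1/N=N/Nc1ccc(C)cc1`: 18300 nM

In a functional assay on HeLa cells (Homo sapiens) for cytotoxicity, read by MTT assay, with a stated time of 48 h (on this read-out higher numbers stand for weaker inhibition of growth and lower numbers for stronger inhibition of growth), compound 1 gives 26100 nM and compound 2 gives 18300 nM. Compound 2 has the lower of the two numbers, but the step of a 1.4-fold lower number from compound 1 to compound 2 (0.15 log units; within the scatter) lies within the scatter, so the two compounds cannot be told apart on these data.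

Compound 3 `CCOC(=O)c1sc2ccccc2c1/N=N/Nc1ccc(OC)cc1` differs from compound 2 by methoxy in place of methyl on an aromatic carbon. Among the measured compounds shown here, the only measured step that bears on this change is a 1.4-fold lower number from compound 1 to compound 2 (0.15 log units; within the scatter), a change at the same aromatic carbon that stayed within the scatter. With a single step, and that one flat, no movement beyond the scatter is expected in this assay from compound 2 to compound 3, a 1.1-fold lower number from compound 2 to compound 3 (0.06 log units; within the scatter). Compound 3 is therefore estimated at 16000 nM, with an expected range from 6000 nM to 45000 nM.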

Compound 3, concentration for 50% growth inhibition: 17400 nM
Estimate against measurement, compound 3: 1.1-fold (0.04 log units) below, within the range that was stated.
By their numbers in this assay, from the lowest: compounds 3, 2 and 1 (each within the scatter of the next).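

In this assay, the change from methyl to methoxy brings in one oxygen and one hydrogen-bond acceptor at this aromatic carbon, yet it gives only a 1.1-fold lower number from compound 2 to compound 3 (0.02 log units; within the scatter). Set against the unsubstituted ring, methoxy gives a 1.5-fold lower number from compound 1 to compound 3 (0.18 log units; within the scatter), so neither replacement of hydrogen at this carbon can be told from the parent, and hydrogen, methyl and methoxy remain indistinguishable here. No measurement is available that would offer an explanation for this flat result.

From the compounds shown here alone, whether this carbon tolerates any group without a readable shift remains open, since an amine, a carboxylic acid, a chlorine atom or a longer chain such as butyl could still behave differently. The compounds shown also leave open whether methoxy on another carbon of this ring would give a result beyond the scatter.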